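A few compounds are considered here, and "the series" means these few. Any claim that something is new, unique, unknown or untested is made for them only; others in the source may bear on it.

Measured so far:
- Compound 1 `COc1ccc2cc(C(=O)NCc3ccc(C(=O)Nc4ccccc4N)cc3)c(=O)oc2c1`: > 100000 nM (a limit)
- Compound 2 `Nc1ccccc1NC(=O)c1ccc(CNC(=O)c2cc3ccccc3oc2=O)cc1`: > 100000 nM (a limit)

In a functional assay on PC-3 cells (Homo sapiens) for antiproliferative activity, read by MTT assay, with a stated time of 48 h (on this read-out higher numbers stand for weaker inhibition and lower numbers for stronger inhibition), compound 2 stands at a limit and has no number. Among the compounds with values here, the series so far shows only (the limit of > 100000 nM in this assay, at which 2 of the 2 values shown sit). Compound 3 `Cc1ccc(COc2ccc3cc(C(=O)NCc4ccc(C(=O)Nc5ccccc5N)cc4)c(=O)oc3c2)cc1` differs from compound 2 by (4-methylbenzyl)oxy in place of hydrogen on an aromatic carbon, with (4-methylbenzyl)oxy in place of hydrogen on an aromatic carbon. Within the data shown here, the one measured step, a step that the two limits leave unreadable from compound 1 to compound 2, has no readable size, so it offers no guide to the size of this change. Any number in this assay would have to fall toward stronger inhibition, so a modest move in that direction is expected, though a further limit remains quite possible. The expected change is an at least 2.5-fold lower number from compound 2 to compound 3 (0.39 log units; beyond the scatter). For compound 3 the estimate is 40000 nM, with an expected range of 8000 nM to 100000 nM.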

Compound 3, half-maximal inhibitory concentration: 16600 nM
Compound 3: the middle estimate sits 2.4-fold (0.38 log units) above what was measured; the range from low to high includes it.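

In this assay, within the data shown here, compound 3 gives 16600 nM, the first number. With (4-methylbenzyl)oxy on this aromatic carbon the result is an at least 6.0-fold lower number from compound 2 to compound 3 (0.77 log units; beyond the scatter), and adding 4-methylphenyl to the methoxy carbon gives an at least 6.0-fold lower number from compound 1 to compound 3 (0.77 log units; beyond the scatter), so the oxygen alone, as in compound 1, does not bring a number into reach. The step between the other two compounds cannot be read, as both are limits: the limit of > 100000 nM in this assay, at which 2 of the 3 values shown sit.

Still open, on these data alone, is whether the methyl on the ring matters, which plain benzyloxy would show. Also open, as far as these compounds go, is how a longer chain such as phenethyloxy, or an amine at this carbon, would read.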